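The source may report more compounds than this note shows. Statements on the series, on what has been measured and on what is new or still open speak of the compounds shown alone.

Among the measured compounds shown here, compound 3 `CN1CCN(c2ccc(Nc3nc(-c4cccc(NC(=O)c5ccc(F)c(Cl)c5)c4)sc3C(=O)O)cc2)CC1` is the stronger of the two measured members of this small series in a functional assay on Ramos cells (Homo sapiens) for antiproliferative activity, read by CCK-8 assay, with a stated time of 72 h (a higher number here means a weaker inhibitor, a lower number a stronger inhibitor), where compound 3 gives 5600 nM. In this assay, for the measured compounds named here, compound 2 `CN1CCN(c2ccc(Nc3nc(-c4cccc(NC(=O)c5cccc(F)c5)c4)sc3C(=O)O)cc2)CC1` gives 14000 nM; the only measured step, a 2.5-fold lower number from compound 2 to compound 3 (0.40 log units; beyond the scatter), separates them. Compound 1 `CN1CCN(c2ccc(Nc3nc(-c4cccc(NC(=O)c5ccccc5)c4)sc3C(=O)O)cc2)CC1` carries the unsubstituted phenyl on the carbonyl carbon, and in this assay compound 1 stands at "not determined" (no result reported), so it adds nothing to the comparison.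

Compound 4 `CN1CCN(c2ccc(Nc3nc(-c4cccc(NC(=O)c5ccc(F)c(Cl)c5)c4)sc3C(N)=O)cc2)CC1` differs from compound 3 at a different position altogether: amino in place of hydroxy on a carbonyl carbon, which, read one bond further out, is carboxy to carbamoyl. Going by the values given here, no measured step in this assay touches that part of the molecule; the step from compound 2 to compound 3 concerns the ring on the other carbonyl carbon and says nothing about what exchanging hydroxy for amino on the core carbonyl will do. Among the compounds with values here, with no precedent to lean on, the expectation for compound 4 can only be that it stays near compound 3, with a wide margin either way.

The estimated step from compound 3 to compound 4 is therefore a 1.1-fold lower number from compound 3 to compound 4 (0.05 log units; within the scatter), essentially no change beyond the scatter. Compound 4 is expected to give about 5000 nM in this assay, with a plausible range from 1000 nM to 25000 nM.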

Compound 4, half-maximal inhibitory concentration: 4830 nM
For compound 4 the middle estimate is 1.0-fold (0.02 log units) above the measured one; measured number inside the range.
By their numbers in this assay, from the lowest: compounds 4 and 3 (each within the scatter of the next); then compound 2.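

In this assay, among the compounds shown here, amino in place of hydroxy on a carbonyl carbon, which is carboxy to carbamoyl, gives a 1.2-fold lower number from compound 3 to compound 4 (0.06 log units; within the scatter), the first measured step at this position and one that shows the carboxy group can be exchanged for carbamoyl here without a change beyond the scatter, at least with the 3-chloro-4-fluorophenyl ring held on the other carbonyl carbon. For the compounds shown here, the only earlier step concerned that other ring, so the two measured steps now cover two separate places on the molecule, and only the step on that ring lies beyond the scatter. No measurement is at hand that would explain why the exchange at the core carbonyl leaves the number within the scatter.

The compounds shown leave open whether a methyl ester, a dimethylamide or a nitrile in place of the carboxy group would also stay in this range. Going by these compounds alone, they also leave open whether the exchange of carboxy for carbamoyl reads the same with the 3-fluorophenyl ring of compound 2 or the unsubstituted phenyl of compound 1, since only one such pair can be read.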